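The compounds below may be only part of what the source reports. "The series", "measured", "known", "first", "only" and "open" are said of these compounds alone.

Measured compounds:
Compound 1 `N#CC1=C(N)Oc2c(c3nc4ccccc4nc3c3ccccc23)C12C(=O)N(Cc1cnnn1-c1cccc(Cl)c1)c1ccccc12` gives 35200 nM in an ADME assay on L02 cells (Homo sapiens) for antiproliferative activity, read by MTT assay, with a stated time of 48 h; on this read-out lower numbers stand for stronger inhibition and higher numbers for weaker inhibition.
Compound 2 `N#CC1=C(N)Oc2c(c3nc4ccccc4nc3c3ccccc23)C12C(=O)N(Cc1cnnn1-c1cccc(Br)c1)c1ccccc12` sits at the limit of this assay, > 50000 nM.
Compound 3 `N#CC1=C(N)Oc2c(c3nc4ccccc4nc3c3ccccc23)C12C(=O)N(Cc1cnnn1-c1cccc(S(N)(=O)=O)c1)c1ccccc12` also sits at the limit of this assay, > 50000 nM.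

For the measured compounds named here, compound 1 holds the only number of the three; the other two values are limits (the limit of > 50000 nM in this assay, at which 2 of the 3 values shown sit). Both measured steps away from compound 1 end at that limit: an at least 1.4-fold higher number from compound 1 to compound 2 (0.15 log units; that floor lies within the scatter) and an at least 1.4-fold higher number from compound 1 to compound 3 (0.15 log units; that floor lies within the scatter), each a floor that lies within the scatter. Compound 4 `Cc1ccc(C)c(-n2nncc2CN2C(=O)C3(C(C#N)=C(N)Oc4c3c3nc5ccccc5nc3c3ccccc43)c3ccccc32)c1` differs from compound 1 by 2,5-dimethylphenyl in place of 3-chlorophenyl on an aromatic nitrogen. Going by the values given here, no measured step swaps the chlorophenyl for a dimethylphenyl, so the two steps give only a weak pointer: neither variation at this position gave a lower number. Compound 4 is therefore expected to stay near compound 1 or drift higher, an expected step of a 1.2-fold higher number from compound 1 to compound 4 (0.08 log units; within the scatter). The estimate for compound 4 is 42000 nM, within 15000 nM to 120000 nM.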

Compound 4, half-maximal inhibitory concentration: > 50000 nM
Compound 4: only a limit was reported (the forecaster's own chance of this, stated with the estimate: 45%); middle value at least 1.1-fold (0.07 log units) from the limit.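

In this assay, 2,5-dimethylphenyl in place of 3-chlorophenyl on the aromatic nitrogen gives an at least 1.4-fold higher number from compound 1 to compound 4 (0.15 log units; that floor lies within the scatter) and so adds a group without halogen or sulfamoyl to those tried at this position. For the compounds shown here, compound 4 also ends at a limit, leaving compound 1 as the only compound with a number: the limit of > 50000 nM in this assay, at which 3 of the 4 values shown sit. The steps from compound 2 and from compound 3 to compound 4 cannot be read. The compounds shown leave open whether an amine or a carboxylic acid on this phenyl ring would give a number lower than that of compound 1.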